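The source may report more compounds than this note shows. Statements on the series, on what has been measured and on what is new or still open speak of the compounds shown alone.

The series shares one core, shown by compound 1 `CNC(=O)c1cc(Oc2ccc(C(=O)/C=C/c3ccc(F)cc3Cl)cc2)ccn1`. Among the compounds with values here, in a functional assay on A549 cells (Homo sapiens) for cytotoxicity, read by MTT assay, with a stated time of 72 h (on this read-out lower numbers stand for stronger inhibition and higher numbers for weaker inhibition), compound 1 gives 21100 nM, the only number available so far. A second member, compound 2 `CNC(=O)c1cc(Oc2ccc(/C=C/C(=O)c3ccc(Cl)cc3)cc2)ccn1`, is recorded in this assay only as "not determined" (no result reported), so nothing can be said of how it compares.

Compound 3 `CNC(=O)c1cc(Oc2ccc(C(=O)/C=C/c3ccc(Cl)cc3Cl)cc2)ccn1` has not yet been measured. It differs from compound 1 in a single place: chloro in place of fluoro on an aromatic carbon. The altered carbon sits meta to a chloro group and para to a large group, so the whole change amounts to swapping one halogen for another on the outer ring.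

Within the data shown here, with only one number in hand, no step between measured compounds exists to guide the guess. Such a swap usually moves cytotoxicity little, and if it moves at all the expectation is toward slightly stronger inhibition. The estimated step of a 1.4-fold lower number from compound 1 to compound 3 (0.15 log units; within the scatter) is therefore small, and compound 3 is expected to give about 15000 nM, within a range of roughly 5000 nM to 45000 nM.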

Compound 3, half-maximal inhibitory concentration: 9460 nM
Compound 3: the middle estimate sits 1.6-fold (0.20 log units) above what was measured; the measured number falls inside the stated range.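

Replacing the 2-chloro-4-fluorophenyl group with 2,4-dichlorophenyl gives, in this assay, a 2.2-fold lower number from compound 1 to compound 3 (0.35 log units; beyond the scatter), so this carbon on the outer ring is not silent: exchanging one halogen for another changes the read-out by a modest amount that lies beyond the usual scatter. Within the data shown here, this is the first step the series offers, and it gives the position a measured direction, with chloro here giving the lower number and so the stronger inhibition of the two compounds compared. No supporting measurement accompanies this pair, so the data offer no explanation for the difference between fluoro and chloro at this carbon.

What the compounds shown leave open is whether this one step reflects a wider trend at this carbon, as a single pair cannot show how bromo, methyl, methoxy, an amine or a carboxylic acid would behave there. It is also unclear whether the same exchange of fluoro for chloro would give a similar step elsewhere on the ring or on a different core, such as that of compound 2, which has no number to compare.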